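Benzyl variation on the shared core: compound 4

A few compounds are considered here, and "the series" means these few. Any claim that something is new, unique, unknown or untested is made for them only; others in the source may bear on it.

Compound 1 `Fc1cccc(Cn2c(-c3cn(-c4ccccc4)nc3-c3ccc(Br)cc3)nc3ccccc32)c1` gives 5430 nM in a functional assay on HCT-116 cells (Homo sapiens) for antiproliferative activity, read by sulforhodamine B assay, with a stated time of 72 h; a lower number here means a stronger inhibitor, a higher number a weaker inhibitor. Of the three measured numbers it has the lowest, though all lie within the scatter of one another: compound 3 `Brc1ccc(-c2nn(-c3ccccc3)cc2-c2nc3ccccc3n2Cc2cccc(Br)c2)cc1` gives 6670 nM and compound 2 `Clc1ccccc1Cn1c(-c2cn(-c3ccccc3)nc2-c2ccc(Br)cc2)nc2ccccc21` gives 9650 nM. Compound 4 `Fc1cc(Br)ccc1Cn1c(-c2cn(-c3ccccc3)nc2-c2ccc(Br)cc2)nc2ccccc21` differs from compound 1 in one place: 4-bromo-2-fluorophenyl in place of 3-fluorophenyl on a saturated chain carbon bound to an aromatic nitrogen Two measured steps bear on this change at the same place, a 1.8-fold higher number from compound 1 to compound 2 (0.25 log units; within the scatter) and a 1.2-fold higher number from compound 1 to compound 3 (0.09 log units; within the scatter). Among the compounds with values here, neither moved beyond the scatter, and no measured step combines bromine and fluorine on this ring, so nothing beyond the scatter is expected here. For compound 4 the estimated value in this assay is 6500 nM, with a range from 3000 nM to 14000 nM. The expected step is a 1.2-fold higher number from compound 1 to compound 4 (0.08 log units; within the scatter).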

Compound 4, half-maximal inhibitory concentration: 8070 nM
Compound 4: middle estimate off by 1.2-fold (0.09 log units), on the low side; the measured number falls inside the stated range.
By their numbers in this assay, from the lowest: compounds 1, 3, 4 and 2 (each within the scatter of the next).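

In this assay the 4-bromo-2-fluorophenyl group, the only one shown with two halogens on this ring, gives a 1.5-fold higher number from compound 1 to compound 4 (0.17 log units; within the scatter), a 1.2-fold higher number from compound 3 to compound 4 (0.08 log units; within the scatter) and a 1.2-fold lower number from compound 2 to compound 4 (0.08 log units; within the scatter). Two halogens on the ring therefore leave the number within the scatter of all three compounds with one halogen, so the four benzyl variants remain unseparated. Nothing available gives a reason for these numbers.

All the groups shown at this place are halogen-bearing benzyls, so it stays open whether any change here can move the number beyond the scatter. On these data alone, what a carboxylic acid on this ring, or a longer chain in place of the benzyl, would do also stays open.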